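Hydroxy for fluoro on the aromatic ring of compound 3

The compounds below may be only part of what the source reports. "The series", "measured", "known", "first", "only" and "open" are said of these compounds alone.

Among the compounds with values here, compound 3 `O[C@@H](c1ccccc1)[C@H]1CO[C@H](c2ccccc2)[C@@H](C/C=C/c2ccccc2F)C1` stands, in a functional assay on HL-60 cells (Homo sapiens) for cytotoxicity, read by WST assay, with a stated time of 48 h (a higher number here means a weaker inhibitor, a lower number a stronger inhibitor), second highest of the three numbers measured so far, at 9530 nM; its nearest neighbour is compound 2 `O[C@@H](c1ccccc1)[C@H]1CO[C@H](c2ccccc2)[C@@H](C/C=C/c2ccc(F)cc2)C1` with 8110 nM, its furthest compound 1 `Oc1cccc(/C=C/C[C@H]2C[C@@H]([C@@H](O)c3ccccc3)CO[C@@H]2c2ccccc2)c1` with 12800 nM. Compound 4 `Oc1ccccc1/C=C/C[C@H]1C[C@@H]([C@@H](O)c2ccccc2)CO[C@@H]1c1ccccc1` differs from compound 3 in one place: hydroxy in place of fluoro on an aromatic carbon. Within the data shown here, three measured steps bear on substituents of this same aromatic ring: a 1.6-fold lower number from compound 1 to compound 2 (0.20 log units; within the scatter); a 1.3-fold lower number from compound 1 to compound 3 (0.13 log units; within the scatter); a 1.2-fold higher number from compound 2 to compound 3 (0.07 log units; within the scatter). All three lie within the scatter, so for compound 4 no step beyond the scatter is expected in this assay in either direction. Compound 4 is therefore estimated at 10000 nM with a range of 5000 nM to 20000 nM. The expected step is a 1.0-fold higher number from compound 3 to compound 4 (0.02 log units; within the scatter).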

Compound 4, half-maximal inhibitory concentration: 10800 nM
Compound 4: the middle estimate sits 1.1-fold (0.03 log units) below what was measured; the range from low to high includes it.
By their numbers in this assay, from the lowest: compounds 2, 3, 4 and 1 (each within the scatter of the next).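

In this assay, hydroxy in place of fluoro on this aromatic carbon, ortho to a large group, gives a 1.1-fold higher number from compound 3 to compound 4 (0.05 log units; within the scatter), so bringing in a hydrogen-bond donor and acceptor here does not separate the two compounds. The 2-hydroxyphenyl compound also stays close to both other aryl variants, with a 1.3-fold higher number from compound 2 to compound 4 (0.12 log units; within the scatter) and a 1.2-fold lower number from compound 1 to compound 4 (0.07 log units; within the scatter), so neither the fluoro-to-hydroxy change nor the other ring variations shown here stand out. Nothing available explains this flatness. Open, on these data alone, is whether an amine, a carboxylic acid or a longer chain on this ring would give a step beyond the scatter.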